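Fluorine on the Pendant Phenyl of Two Related Cores

The source may hold more compounds than are shown below. What is called first, only, known or untested is meant among the compounds shown, and "the series" means these compounds.

Measured compounds:
compound 1 `Cc1c(/C=N\O)cc(-c2ccc(S(C)(=O)=O)cc2)n1-c1ccc(F)cc1`, 47%
compound 2 `Cc1c(/C=N\O)cc(-c2ccc(S(C)(=O)=O)cc2)n1-c1ccccc1`, 57%
compound 3 `Cc1c(C#N)cc(-c2ccc(S(C)(=O)=O)cc2)n1-c1cccc(F)c1`, 38%

All three were tested in a functional assay on the whole organism (strain Swiss albino) for inhibition, with Mus musculus as the target, in the writhing test, with a stated time of 30 min, at a dose of 40 mg/kg by the oral route; a higher number here means a stronger effect of the compound at the dose given, a lower number a weaker effect. Compound 2 gives 57%, and compound 1, which carries one extra fluorine, gives 47%. The change between them is fluoro in place of hydrogen on an aromatic carbon, and the step it made is a number 10 percentage points lower from compound 2 to compound 1 (within the scatter). Compound 3 has a different core, and the difference between the two cores is not broken down here; in this assay compound 3 gives 38%, which lies within the scatter of compound 1 but beyond it relative to compound 2.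

Compound 4 `Cc1c(C#N)cc(-c2ccc(S(C)(=O)=O)cc2)n1-c1ccc(F)c(F)c1` has not been measured. It differs from compound 3 by fluoro in place of hydrogen on an aromatic carbon. This is the same kind of change as that from compound 2 to compound 1, but not the same: here the new fluoro sits ortho to a fluoro group, whereas in compound 1 it is only para to a large group. Going by the values given here, because the only measured instance, a number 10 percentage points lower from compound 2 to compound 1 (within the scatter), stayed within the scatter, a similar small step is expected for compound 4, namely a number 6 percentage points lower from compound 3 to compound 4 (within the scatter). Compound 4 is therefore estimated to give 32% in this assay, with a plausible range from 18% to 46%.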

Compound 4, a percentage reported as inhibition, in the whole organism at one dose (the size of the read-out at that dose, not a potency): 57%
Estimate against measurement, compound 4: 25 percentage points below; measured number above the stated range.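

In this assay, placing a second fluoro on the pendant ring, which turns 3-fluorophenyl into 3,4-difluorophenyl, gave a number 19 percentage points higher from compound 3 to compound 4 (beyond the scatter). This shows that, in these two pairs, the same kind of change does not carry over from one core to the other as a fixed step, so the result on one core gives no safe forecast for the other: the same change on two cores in this assay, a number 10 percentage points lower (within the scatter) from compound 2 to compound 1 and a number 19 percentage points higher (beyond the scatter) from compound 3 to compound 4, 29 percentage points apart, beyond the scatter of two such steps. Going by these compounds alone, it does not show that the core alone sets the outcome: the new fluoro in compound 4 stands ortho to a fluoro group, while the one in compound 1 has no such fluoro neighbour, so core and surroundings change together, and two pairs cannot separate them or establish a rule for the series.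

The compounds shown leave open how a single fluoro would behave on the core of compound 3 when it stands para to the large group with no other fluoro on the ring, which would help to tell those two explanations apart. They also leave open whether a chloro, a methoxy or an amino group in that same place would follow the step seen with fluoro on either core.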